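Chloro added to a dihydroxy pyrazole analogue

This account rests on a few compounds, and the source may have more. Where it says the series, first, only, none or still open, it means among the compounds named here.

Compounds measured so far:
- compound 1 `COc1ccc(OC)c(-c2cc(-c3ccc(Cl)cc3)nn2-c2ccccc2)c1`: 49000 nM
- compound 2 `COc1ccc(OC)c(-c2cc(-c3ccccc3)nn2-c2ccc(S(=O)(=O)NC(C)=O)cc2)c1`: 13300 nM
- compound 3 `Oc1ccc(O)c(-c2cc(-c3ccccc3)nn2-c2ccccc2)c1`: 37700 nM

In a functional assay on cells (Cancer cell lines, Homo sapiens) for cytotoxicity, read by sulforhodamine B assay, with a stated time of 48 h (on this read-out higher numbers stand for weaker inhibition of growth and lower numbers for stronger inhibition of growth), compound 1 gives 49000 nM, compound 2 gives 13300 nM and compound 3 gives 37700 nM. Compound 3 and compound 1 sit within the usual scatter of each other, so nothing can be said about which of the two inhibits growth more. Compound 2 gives a clearly lower number than compound 3, a gap beyond the scatter.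

Compound 4 `Oc1ccc(O)c(-c2cc(-c3ccc(Cl)cc3)nn2-c2ccccc2)c1` has not yet been measured. It differs from compound 3 in one place: chloro in place of hydrogen on an aromatic carbon. Within the data shown here, no measured pair in this set isolates this change, so its effect is unknown here. Compound 1 already carries the same 4-chlorophenyl group and gives 49000 nM, a number close to that of compound 3. The expected step from compound 3 to compound 4 in this assay is therefore small, a 1.1-fold higher number from compound 3 to compound 4 (0.03 log units; within the scatter), in no direction beyond the scatter. Compound 4 is estimated at 40000 nM, with a likely range from 15000 nM to 100000 nM.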

Compound 4, concentration for 50% growth inhibition: 8010 nM
Compound 4: middle estimate off by 5.0-fold (0.70 log units), on the high side; the whole stated range lies above it.
By their numbers in this assay, from the lowest: compounds 4 and 2 (each within the scatter of the next); then compounds 3 and 1 (each within the scatter of the next).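

In this assay, among these compounds, the change from phenyl to 4-chlorophenyl gives a 4.7-fold lower number from compound 3 to compound 4 (0.67 log units; beyond the scatter), the first pair here to isolate this change. It shows that this position, on the aromatic ring and para to a large group, responds to a single added chlorine atom, with a modest step that lies beyond the usual scatter. No measurement shown here accounts for this step.

Compound 1 also carries the 4-chlorophenyl group but has no partner with a plain phenyl, so whether the change acts the same way on its methoxy-bearing core cannot be read. Going by these compounds, it also remains open whether chlorine itself matters or whether fluoro, bromo, methyl or an amine in the same place would give a similar step.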